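A Halogen Swap on the Aryl Ketone of Compound 2

The source may hold more compounds than are shown below. What is called first, only, known or untested is meant among the compounds shown, and "the series" means these compounds.

Compound 1 `Cc1nnc(SCC(=O)c2ccc(Cl)cc2)n1N1C(=O)c2ccccc2C1=O`: > 200000 nM
Compound 2 `COc1cc(-c2nnc(SCC(=O)c3ccc(Cl)cc3)n2N2C(=O)c3ccccc3C2=O)cc(OC)c1OC`: 9030 nM

In a functional assay on A549 cells (Homo sapiens) for cytotoxicity, read by MTT assay, with a stated time of 48 h (a lower number here means a stronger inhibitor, a higher number a weaker inhibitor), compound 1 gives only a limit, > 200000 nM, namely (the limit of > 200000 nM in this assay, at which 1 of the 2 values shown sits). Going by the values given here, compound 2 gives 9030 nM in this assay, the only real number among the two. Among the compounds with values here, the single measured step, an at least 22-fold lower number from compound 1 to compound 2 (1.34 log units; beyond the scatter), sits at a different place and does not bear on the change considered here. Compound 3 `COc1cc(-c2nnc(SCC(=O)c3ccc(F)c(F)c3)n2N2C(=O)c3ccccc3C2=O)cc(OC)c1OC` differs from compound 2 by 3,4-difluorophenyl in place of 4-chlorophenyl on a carbonyl carbon. Within the data shown here, with no measured step at this position, no change beyond the scatter is expected. Compound 3 is estimated at 12000 nM, with a range from 4000 nM to 40000 nM. The expected step is a 1.3-fold higher number from compound 2 to compound 3 (0.12 log units; within the scatter).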

Compound 3, half-maximal inhibitory concentration: > 200000 nM
Compound 3 gave a limit, no number; the forecaster's own chance of this, stated with the estimate: 10%; middle value at least 16-fold (1.22 log units) away from the limit.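

In this assay, going by these compounds alone, replacing 4-chlorophenyl with 3,4-difluorophenyl on the carbonyl carbon gives an at least 22-fold higher number from compound 2 to compound 3 (1.34 log units; beyond the scatter), so this position, unchanged among the earlier compounds, can also decide the read-out. From the compounds shown here alone, the result for compound 3 is a limit, so the full size of the step stays unknown. Compound 2 remains the only compound here with a real number, while the other two sit at the same limit: the limit of > 200000 nM in this assay, at which 2 of the 3 values shown sit.

Going by these compounds, it remains open whether losing the chlorine or gaining the two fluorines drives this step. Also open, on these data alone, is whether 4-bromophenyl or 4-methoxyphenyl at this place would stay near compound 2.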